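Cytotoxicity notes: aryl swap on the amide nitrogen

A few compounds are considered here, and "the series" means these few. Any claim that something is new, unique, unknown or untested is made for them only; others in the source may bear on it.

compound 1 `COC(=O)C[C@H](NC(=O)OC(C)(C)C)C(=O)NC1(C(=O)NCc2ccccc2)CCN(Cc2ccccc2)CC1`: 100000 nM
compound 2 `COC(=O)C[C@H](NC(=O)OC(C)(C)C)C(=O)N(Cc1ccc(C(F)(F)F)cc1)C1(C(=O)NCc2ccccc2)CCN(Cc2ccccc2)CC1`: 84000 nM

Going by the values given here, in an ADME assay on MDCK cells (Canis lupus familiaris) for cytotoxicity, read by microscopy, with a stated time of 72 h (on this read-out higher numbers stand for lower toxicity in this test and lower numbers for higher toxicity in this test), compound 1 gives 100000 nM and compound 2 gives 84000 nM; the two lie within the scatter of each other, the only measured step being a 1.2-fold lower number from compound 1 to compound 2 (0.08 log units; within the scatter). Compound 3 `COC(=O)C[C@H](NC(=O)OC(C)(C)C)C(=O)N(Cc1ccc(F)c(F)c1)C1(C(=O)NCc2ccccc2)CCN(Cc2ccccc2)CC1` differs from compound 2 by 3,4-difluorophenyl in place of 4-(trifluoromethyl)phenyl on a saturated chain carbon bound to an amide-type nitrogen. No measured step addresses a change within the benzyl on this nitrogen; the one step shown, a 1.2-fold lower number from compound 1 to compound 2 (0.08 log units; within the scatter), adds the whole group and stays within the scatter. Compound 3 is therefore expected to show a 1.1-fold higher number from compound 2 to compound 3 (0.03 log units; within the scatter), with the estimated value 90000 nM and the range 40000 nM to 200000 nM.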

Compound 3, minimum cytotoxic concentration: 20000 nM
Compound 3: the middle estimate sits 4.5-fold (0.65 log units) above what was measured; measured number below the stated range.
By their numbers in this assay, from the lowest: compound 3; then compounds 2 and 1 (each within the scatter of the next).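

In this assay the position proves sensitive to what the benzyl carries: 3,4-difluorophenyl in place of 4-(trifluoromethyl)phenyl gives a 4.2-fold lower number from compound 2 to compound 3 (0.62 log units; beyond the scatter) on this read-out. Set against the amide hydrogen, 3,4-difluorobenzyl gives a 5.0-fold lower number from compound 1 to compound 3 (0.70 log units; beyond the scatter) and so, unlike 4-(trifluoromethyl)benzyl, moves the number beyond the scatter. No evidence at hand explains this difference between the two benzyl groups. Still open, on these data alone, is whether the lower number tracks the two fluorines or the absence of trifluoromethyl, and how a benzyl carrying an amine or a carboxylic acid would read here.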